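Para substituent swap on the benzamide of a dodecyltetrazole series

This account rests on a few compounds, and the source may have more. Where it says the series, first, only, none or still open, it means among the compounds named here.

Compound 1 `CCCCCCCCCCCCn1nnc(C(NC(=O)c2c(C)cccc2C)c2ccccc2)n1`: 310 nM
Compound 2 `CCCCCCCCCCCCn1nnc(C(NC(=O)c2ccc(Cl)cc2)c2ccccc2)n1`: 440 nM
Compound 3 `CCCCCCCCCCCCn1nnc(C(NC(=O)c2ccc(C)cc2)c2ccccc2)n1`: 510 nM

In an assay on microsomes from liver for inhibition of sterol O-acyltransferase 1 (Rattus norvegicus) (a higher number here means a weaker inhibitor, a lower number a stronger inhibitor), compound 3 gives 510 nM, the highest of the three numbers, yet its distance from the others is small: a 1.2-fold higher number from compound 2 to compound 3 (0.06 log units; within the scatter) and a 1.6-fold higher number from compound 1 to compound 3 (0.22 log units; within the scatter) both stay within the scatter, so the three compounds are not told apart by this assay.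

Compound 4 `CCCCCCCCCCCCn1nnc(C(NC(=O)c2ccc([N+](=O)[O-])cc2)c2ccccc2)n1` is the next member, and it differs from compound 3 in one place: nitro in place of methyl on an aromatic carbon. The step that bears most directly on it is the earlier swap at the same position, a 1.2-fold higher number from compound 2 to compound 3 (0.06 log units; within the scatter), which did not leave the scatter. The two changes of the whole aryl group on the carbonyl carbon, a 1.4-fold higher number from compound 1 to compound 2 (0.15 log units; within the scatter) and a 1.6-fold higher number from compound 1 to compound 3 (0.22 log units; within the scatter), were also within the scatter. Going by the values given here, nothing measured so far points to a para substituent on this ring moving the number beyond the scatter, though only two such substituents have been tried.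

Compound 4 is therefore expected to stay near compound 3, with a step of a 1.1-fold lower number from compound 3 to compound 4 (0.03 log units; within the scatter). The estimate for compound 4 in this assay is 480 nM, with a range from 220 nM to 1100 nM.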

Compound 4, half-maximal inhibitory concentration: 540 nM
Estimate against measurement, compound 4: 1.1-fold (0.05 log units) below, and the stated range covers the measured number.
By their numbers in this assay, from the lowest: compounds 1, 2, 3 and 4 (each within the scatter of the next).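

In this assay the change from methyl to nitro on the aromatic carbon para to a large group brings in more heavy atoms and two hydrogen-bond acceptors, yet the result is small (a 1.1-fold higher number from compound 3 to compound 4 (0.02 log units; within the scatter)). The swap from chloro to nitro at the same position is just as small (a 1.2-fold higher number from compound 2 to compound 4 (0.09 log units; within the scatter)), so a third substituent there, and the first with hydrogen-bond acceptors, joins chloro and methyl without leaving the scatter. Replacing the whole 2,6-dimethylphenyl group with 4-nitrophenyl also stays within it (a 1.7-fold higher number from compound 1 to compound 4 (0.24 log units; within the scatter)), and the four aryl groups on the carbonyl carbon therefore remain untold apart by this read-out. No measurement at hand explains why these groups read alike.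

Going by these compounds, whether an amine or a carboxylic acid at this position would take the number beyond the scatter remains open. The four compounds also share the dodecyl chain and the phenyl group on the central carbon, so they leave open what a shorter chain or a different group in that place would do.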